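The source may hold more compounds than are shown below. What is called first, only, known or untested is meant among the compounds shown, and "the series" means these compounds.

In a functional assay on JeKo-1 cells (Homo sapiens) for inhibition, read by luminescence and CellTiter-Glo, with a stated time of 72 h (on this read-out lower numbers stand for stronger inhibition and higher numbers for weaker inhibition), compound 2 `C=CC(=O)N1CCCC(n2nc(-c3ccc(Oc4ccccc4)cc3)cc2C(=O)OCC)C1` gives 21200 nM as the higher of the two exact numbers in this small set. Within the data shown here, compound 3 `CCOC(=O)c1cc(-c2ccc(Oc3ccccc3)cc2)nn1C1CCCN(C(=O)CCl)C1` gives 800 nM as the only lower number, which is a 27-fold lower number from compound 2 to compound 3 (1.42 log units; beyond the scatter) with chloromethyl in place of vinyl on a carbonyl carbon. Compound 1 `C=CC(=O)N1CCCC(n2nc(-c3ccc(Oc4ccccc4)cc3)cc2C(=O)O)C1` reads > 60000 nM and this value is a limit of the assay. Ethyl in place of hydrogen on an oxygen next to a carbonyl group gives an at least 2.8-fold lower number from compound 1 to compound 2 (0.45 log units; beyond the scatter) as the only measured step at the ester end.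

Among the measured compounds shown here, compound 4 `C=CC(=O)N1CCCC(n2nc(-c3ccc(Oc4ccccc4)cc3)cc2CO)C1` keeps the vinyl of compound 2 and has hydroxymethyl in place of ethoxycarbonyl on an aromatic carbon as its single change. The large step to compound 3 lies at the vinyl and so says little here, whereas an at least 2.8-fold lower number from compound 1 to compound 2 (0.45 log units; beyond the scatter) at least touches the same place and is far smaller. In this assay the expected change is a 1.2-fold higher number from compound 2 to compound 4 (0.09 log units; within the scatter) and so no step beyond the scatter. For compound 4 the estimate is 26000 nM with an expected range from 9000 nM to 60000 nM as its bounds.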

Compound 4, half-maximal inhibitory concentration: 11900 nM
Compound 4: middle estimate off by 2.2-fold (0.34 log units), on the high side, within the range that was stated.
By their numbers in this assay, from the lowest: compound 3; then compounds 4 and 2 (each within the scatter of the next). At a limit, above all of these: compound 1.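

In this assay, the ethoxycarbonyl on this aromatic carbon can be replaced by the smaller hydroxymethyl without a change beyond the scatter: the replacement gives a 1.8-fold lower number from compound 2 to compound 4 (0.25 log units; within the scatter). Hydroxymethyl in place of carboxy on the same carbon gives an at least 5.0-fold lower number from compound 1 to compound 4 (0.70 log units; beyond the scatter), so among the three groups shown at this place, only the carboxy of compound 1 stands apart. Compound 1 sits at a limit, so this step is a bound and not a measured size: the limit of > 60000 nM in this assay, at which 1 of the 4 values shown sits.

From the compounds shown here alone, it remains open whether hydroxymethyl at this carbon would hold up alongside the chloromethyl carbonyl group of compound 3, since all the comparisons at this place carry the vinyl carbonyl group. Going by these compounds, how an amine, a primary amide or a longer hydroxyalkyl chain would read at this carbon also remains open.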